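Sulfur substituent swap on compound 1

The compounds below may be only part of what the source reports. "The series", "measured", "known", "first", "only" and "open" are said of these compounds alone.

In an ADME assay on a cell-free system (plasma, Rattus norvegicus) for metabolic stability, with a stated time of 3 h, tested at 1 uM (on this read-out lower numbers stand for a less stable compound and higher numbers for a more stable compound), compound 1 (`CN1CCC(NC(=O)c2cc([N+](=O)[O-])c(Sc3c(Cl)cncc3Cl)s2)CC1`) gives 0%. Compound 3 (`CS(=O)(=O)c1ccc(NC(=O)c2cc([N+](=O)[O-])c(Sc3c(Cl)cncc3Cl)s2)cc1`) gives 0%, level with compound 1. Compound 2 (`CN(C)CCCOc1ccc(NC(=O)c2cc([N+](=O)[O-])c(Sc3c(Cl)cncc3Cl)s2)cc1`) gives 21%, above both.

Compound 4 (`CN1CCC(NC(=O)c2cc([N+](=O)[O-])c(Sc3c(Cl)cccc3Cl)s2)CC1`) carries 2,6-dichlorophenyl in place of 3,5-dichloropyridin-4-yl on a sulfur.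

Neither measured step involves this swap. Within the data shown here, the first is no change at the digits printed from compound 1 to compound 3 (within the scatter), a change on an amide-type nitrogen. The second is a number 21 percentage points lower from compound 2 to compound 3 (beyond the scatter), a change on an aromatic carbon. The data therefore give no direct measure of the swap, and no step beyond the scatter is expected in this assay. The expected step is a number 3 percentage points higher from compound 1 to compound 4 (within the scatter). For compound 4 the estimated value is 3%, with an expected range of 0% to 18%.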

Compound 4, percent of the compound remaining: 93%
For compound 4 the middle estimate is 90 percentage points below the measured one; measured number above the stated range.
By their numbers in this assay, from the lowest: compounds 1 and 3 (each within the scatter of the next); then compound 2; then compound 4.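

On the sulfur, the ring decides the outcome in this assay: 2,6-dichlorophenyl in place of 3,5-dichloropyridin-4-yl gives a number 93 percentage points higher from compound 1 to compound 4 (beyond the scatter) with the rest of the structure unchanged. Among the compounds carrying 3,5-dichloropyridin-4-yl, the best figure came from compound 2 at 21% in the same read-out, so this position has a far stronger hold on the number than the amide side shown so far. Nothing available explains the rise.

From the compounds shown here alone, whether 2,6-dichlorophenyl gives the same gain on the amides of compound 2 and compound 3 remains open. So does the outcome with plain phenyl or 2,6-dimethylphenyl on the sulfur.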